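Amide-aryl variation on the shared core: compound 4

A few compounds are considered here, and "the series" means these few. Any claim that something is new, unique, unknown or untested is made for them only; others in the source may bear on it.

Compound 1 `CN(C)C(=O)c1cc2cnc(Nc3ccc(NC(=O)C4(C(=O)Nc5ccc(F)cc5)CC4)cc3)nc2n1C1CCCC1` gives 74.7% in a functional assay on T47D cells (Homo sapiens) for inhibition, read by CCK-8 assay, with a stated time of 72 h, tested at 1 uM; on this read-out higher numbers stand for more inhibition of growth at the one concentration tested and lower numbers for less inhibition of growth. Among the three measured compounds it holds the lowest number, but both neighbours sit within the scatter: a number 1.7 percentage points higher from compound 1 to compound 3 (within the scatter) to compound 3 `COc1ccc(NC(=O)C2(C(=O)Nc3ccc(Nc4ncc5cc(C(=O)N(C)C)n(C6CCCC6)c5n4)cc3)CC2)cc1`, which gives 76.4%, and a number 6 percentage points higher from compound 1 to compound 2 (within the scatter) to compound 2 `CN(C)C(=O)c1cc2cnc(Nc3ccc(NC(=O)C4(C(=O)Nc5cccc(O)c5)CC4)cc3)nc2n1C1CCCC1`, which gives 80.7%. Between those two, a number 4.3 percentage points lower from compound 2 to compound 3 (within the scatter) is likewise within the scatter.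

Compound 4 `COc1cccc(NC(=O)C2(C(=O)Nc3ccc(Nc4ncc5cc(C(=O)N(C)C)n(C6CCCC6)c5n4)cc3)CC2)c1` differs from compound 1 in one place: 3-methoxyphenyl in place of 4-fluorophenyl on an amide-type nitrogen. For the measured compounds named here, the steps that bear on this are the aryl swap on the same amide-type nitrogen, a number 6 percentage points higher from compound 1 to compound 2 (within the scatter), and the exchange of methoxy for fluoro on an aromatic carbon, a number 1.7 percentage points higher from compound 1 to compound 3 (within the scatter); neither left the scatter. The same outcome is expected here, a step of a number 2.3 percentage points higher from compound 1 to compound 4 (within the scatter) that stays within the scatter, with no direction claimed.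

Compound 4 is therefore estimated at 77%, with a range from 67% to 87%.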

Compound 4, percent growth inhibition at one concentration: 56.3%
Estimate against measurement, compound 4: 20.7 percentage points above, outside the stated range (below it).
By their numbers in this assay, from the lowest: compound 4; then compounds 1, 3 and 2 (each within the scatter of the next).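

For the compounds shown here, this amide-aryl position, flat across the first three compounds, is not indifferent to the aryl group: 3-methoxyphenyl in place of 4-fluorophenyl gives a number 18.4 percentage points lower from compound 1 to compound 4 (beyond the scatter) in this assay, the first step to leave the scatter. The methoxy group alone does not account for the loss, since the swap from 4-methoxyphenyl gives a number 20.1 percentage points lower from compound 3 to compound 4 (beyond the scatter), so these two methoxyphenyl groups are not interchangeable here, and capping the oxygen of the 3-hydroxyphenyl group with methyl gives a number 24.4 percentage points lower from compound 2 to compound 4 (beyond the scatter). No data at hand explain these drops.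

Still open, as far as these compounds go, is whether the loss is tied to methoxy or extends to an ethoxy group or an amine in its place. Also open, from the compounds shown here alone, is whether a 4-hydroxyphenyl group would match 4-methoxyphenyl or 3-hydroxyphenyl.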